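Trimming the hydroxycarbamoyl chain of compound 1

The source may hold more compounds than are shown below. What is called first, only, known or untested is meant among the compounds shown, and "the series" means these compounds.

In a functional assay on HCT-116 cells (Homo sapiens) for inhibition, read by MTT assay, with a stated time of 72 h (on this read-out lower numbers stand for stronger inhibition and higher numbers for weaker inhibition), compound 1 `Nc1ncnc2c1c(-c1cnc3[nH]ccc3c1)nn2CCCCCCCCC(=O)NO` gives 5460 nM, the lowest of the three numbers available. Compound 2 `Nc1nc2cc(-c3nn(CCCC(=O)NO)c4ncnc(N)c34)ccc2o1` gives 19600 nM, and compound 3 `Nc1nc2cc(-c3nn(CCCCCCCCCC(=O)NO)c4ncnc(N)c34)ccc2o1` gives 23100 nM. Both lie beyond the scatter above compound 1, and both carry a different group on the shared core.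

The unmeasured compound 4 `Nc1ncnc2c1c(-c1cnc3[nH]ccc3c1)nn2CCCCCCC(=O)NO` keeps the core of compound 1 and changes only the chain: hydroxycarbamoyl in place of 2-(hydroxycarbamoyl)ethyl on a saturated chain carbon, six bonds along the chain from an aromatic nitrogen. In words, hydroxycarbamoyl stands in place of 2-(hydroxycarbamoyl)ethyl on a saturated chain carbon, six bonds along the chain from an aromatic nitrogen.

Within the data shown here, only one measured step bears on this change of chain length: a 1.2-fold higher number from compound 2 to compound 3 (0.07 log units; within the scatter). There, 6-(hydroxycarbamoyl)hexyl stands in place of hydroxycarbamoyl, a larger change than the one at issue here, and the step stays within the scatter. That pair carries the other group on the core, and no change of chain length has been measured with the group of compound 1, so the guide is indirect. On that evidence, no step beyond the scatter is expected in this assay. The estimated step is a 1.1-fold lower number from compound 1 to compound 4 (0.04 log units; within the scatter). For compound 4 the expected value is 5000 nM, within an estimated range of 1800 nM to 14000 nM.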

Compound 4, half-maximal inhibitory concentration: 9860 nM
For compound 4 the middle estimate is 2.0-fold (0.29 log units) below the measured one, and the stated range covers the measured number.
By their numbers in this assay, from the lowest: compounds 1, 4, 2 and 3 (each within the scatter of the next, the first and the last beyond it).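

In this assay, among these compounds, the change from 2-(hydroxycarbamoyl)ethyl to hydroxycarbamoyl on a saturated chain carbon, six bonds along the chain from an aromatic nitrogen, gives a 1.8-fold higher number from compound 1 to compound 4 (0.26 log units; within the scatter) and is the first measured change of chain length on the core of compound 1. The chain can thus be trimmed in this way on that core without a step beyond the scatter, something the step of a 1.2-fold higher number from compound 2 to compound 3 (0.07 log units; within the scatter) could suggest only indirectly, as that pair carries the other group on the core. With both groups, the chain changes shown therefore stay within the scatter, but no measurement shown here accounts for the size of either step.

Among the compounds shown here, what remains open is whether a much shorter chain, such as the one in compound 2, or a longer chain than that of compound 1, would stay within the scatter on the core of compound 1. Going by these compounds, it is also open how a carboxylic acid or a primary amide in place of hydroxycarbamoyl would read on this chain.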